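The compounds below may be only part of what the source reports. "The series", "measured", "known", "first", "only" and "open" are said of these compounds alone.

Measured so far:
compound 1 `COc1c(Br)cc(Br)cc1Oc1ccc(Br)cc1Br` — 34.5 ug/mL
compound 2 `BrCCCCCOc1c(Br)cc(Br)cc1Oc1ccc(Br)cc1Br` — 29.5 ug/mL

In a functional assay on U-937 cells (Homo sapiens) for cytotoxicity, read by MTT assay, with a stated time of 24 h (a higher number here means a weaker inhibitor, a lower number a stronger inhibitor), compound 2 holds the lowest of the two numbers; compound 1 is nearest, and the gap a 1.2-fold lower number from compound 1 to compound 2 (0.07 log units; within the scatter) lies within the scatter. Compound 3 `CC(=O)Oc1c(Br)cc(Br)cc1Oc1ccc(Br)cc1Br` follows from compound 2 by acetyl in place of 5-bromopentyl on an oxygen on an aromatic ring. Among the compounds with values here, the only step that bears on this position is the one from compound 1 to compound 2, which stayed within the scatter; it offers no ground for a shift beyond the scatter in this assay in either direction. Compound 3 is therefore expected near compound 2, at 32 ug/mL (range 15 ug/mL to 65 ug/mL), a step of a 1.1-fold higher number from compound 2 to compound 3 (0.04 log units; within the scatter).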

Compound 3, half-maximal inhibitory concentration: 32.3 ug/mL
Estimate against measurement, compound 3: 1.0-fold (0.00 log units) below, within the range that was stated.
By their numbers in this assay, from the lowest: compounds 2, 3 and 1 (each within the scatter of the next).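

In this assay acetyl on an oxygen on an aromatic ring gives a 1.1-fold higher number from compound 2 to compound 3 (0.04 log units; within the scatter) and a 1.1-fold lower number from compound 1 to compound 3 (0.03 log units; within the scatter) as its two steps. This position therefore takes a carbonyl group as well as the two saturated chains, methyl and 5-bromopentyl, without any step beyond the scatter among these three compounds. No data on hand offer an explanation for this flat reading.

Still open, from the compounds shown here alone, is whether an amine, a carboxylic acid or a free hydroxyl at this oxygen would move the number beyond the scatter.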